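Chain substituent at the thioether carbon in a chloropyrimidine series

The source may hold more compounds than are shown below. What is called first, only, known or untested is meant among the compounds shown, and "the series" means these compounds.

Measured so far:
- compound 1, `CCCCCCC(Sc1nc(Cl)cc(Nc2cccc(C)c2C)n1)C(=O)OCC`: 84.9%
- compound 2, `CCOC(=O)CSc1nc(Cl)cc(Nc2cccc3c2CCC3)n1`: 65.2%
- compound 3, `CCOC(=O)CSc1nc(Cl)cc(OCc2ccc3ncccc3c2)n1`: 80%

All three were run in an assay for inhibition of Polyunsaturated fatty acid 5-lipoxygenase (Homo sapiens), tested at 1 uM; a higher number here means a weaker effect of the compound at the concentration tested, a lower number a stronger effect. Compound 1 gives the highest of the three numbers, 84.9%, which is a weak effect at this concentration. The gap to compound 3 is within the scatter, so the two cannot be told apart; compound 2 lies beyond the scatter below compound 1, the one clear difference among the measured set. Among the compounds with values here, no two measured compounds differ in a single place, so nothing can be read off as a single step.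

Compound 4, `CCOC(=O)C(C)Sc1nc(Cl)cc(Nc2cccc(C)c2C)n1`, has not been measured. Against compound 1 the difference is hydrogen in place of pentyl on a saturated chain carbon, two bonds along the chain from a carbonyl carbon and a sulfur. The shared core, the chloro substituent and the aryl amine are kept; only the chain at the thioether carbon shrinks.

Both compounds that carry a short chain at that carbon, compound 2 and compound 3, sit at or below compound 1, but they differ elsewhere as well. The step of a number 5.9 percentage points lower from compound 1 to compound 4 (within the scatter) is therefore expected to be small and, if anything, downward, not clearly beyond the scatter. Compound 4 is estimated at 79%, with a range from 64% to 92%.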

Compound 4, a percentage reported as activity, at one concentration (the size of the read-out at that concentration, not a potency): "not active" (no number reported)
Compound 4 has no reported number here; no gap can be computed for the estimate.
By their numbers in this assay, from the lowest: compound 2; then compounds 3 and 1 (each within the scatter of the next).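

In this assay, within the data shown here, compound 4 is reported as "not active" without a number, so no step from compound 1 to compound 4 can be read. The compounds shown leave open how much the change from pentyl to hydrogen at the thioether carbon alters the read-out. No measured evidence bears on this result.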